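Difluoromethoxy to methoxy on two related cores

The compounds below may be only part of what the source reports. "The series", "measured", "known", "first", "only" and "open" are said of these compounds alone.

Measured so far in a functional assay on SH-SY5Y cells (Homo sapiens) for antiproliferative activity, read by MTT assay, with a stated time of 48 h; a lower number here means a stronger inhibitor of growth, a higher number a weaker inhibitor of growth:
compound 1 `COc1ccccc1OCCNc1ccc(=O)n(Cc2ccc(OC)c(OC3CCCC3)c2)n1` gives > 100000 nM, a limit of the assay.
compound 2 `COc1ccccc1OCCNc1ccc(=O)n(Cc2ccc(OC(F)F)c(OC3CCCC3)c2)n1` gives 9300 nM.
compound 3 `COc1ccccc1OCCNc1cnn(Cc2ccc(OC(F)F)c(OC3CCCC3)c2)c(=O)c1Cl` gives > 100000 nM, a limit of the assay.

Compound 2 and compound 1 share one core and differ in a single place: methyl in place of difluoromethyl on an oxygen on an aromatic ring. That change produced an at least 10-fold higher number from compound 2 to compound 1 (1.03 log units; beyond the scatter). Since the number for compound 1 is only a limit, the true size of that step is open at the upper end; the pair sits against (the limit of > 100000 nM in this assay, at which 2 of the 3 values shown sit).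

Compound 3 carries a different core; the difference between the two cores is not broken down here. Within its own series compound 3 already sits at the limit in this assay.

Compound 4 `COc1ccccc1OCCNc1cnn(Cc2ccc(OC)c(OC3CCCC3)c2)c(=O)c1Cl` has not yet been measured. It stands to compound 3 as compound 1 stands to compound 2, with the same change in the same place: methyl in place of difluoromethyl on an oxygen on an aromatic ring.

Two things bear on what to expect. The change from compound 2 to compound 1 weakened growth inhibition strongly, as an at least 10-fold higher number from compound 2 to compound 1 (1.03 log units; beyond the scatter) shows. And compound 3, the starting point here, already gives only a limit. The step from compound 3 to compound 4 is therefore expected to be a step that the limit leaves unreadable from compound 3 to compound 4 in this assay, and in practice another limit. Compound 4 is estimated at 300000 nM in this assay, most likely again reported only as a limit, within 100000 nM to 3000000 nM.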

Compound 4, concentration for 50% growth inhibition: 23300 nM
The estimate for compound 4 lay 13-fold (1.11 log units) above the measured number, outside the stated range (below it).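

On the core of compound 3, the change from difluoromethoxy to methoxy in this assay gave an at least 4.2-fold lower number from compound 3 to compound 4 (0.63 log units; beyond the scatter), so compound 4 is the stronger inhibitor of growth of this pair, at 23300 nM. The effect of this change therefore does not carry from one core to the other, and its direction reverses: the same change on two cores in this assay, an at least 10-fold higher number (1.03 log units; beyond the scatter) from compound 2 to compound 1 and an at least 4.2-fold lower number (0.63 log units; beyond the scatter) from compound 3 to compound 4, at least 46-fold (1.66 log units) apart, beyond the scatter of two such steps. One end of each step is a limit, so the true sizes of both steps and of the gap between them stay open, and two cores neither give a rule for any further core nor explain the reversal: the limit of > 100000 nM in this assay, at which 2 of the 4 values shown sit.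

The compounds shown leave open which part of the difference between the two cores goes with the reversal, since no compound separates that difference into single changes. They also leave open how an ethoxy or trifluoromethoxy group in place of difluoromethoxy would behave on each core, and whether such groups would follow the order seen in compound 1 and compound 2 or the opposite order seen in compound 3 and compound 4.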